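Notes on the Side-Chain Change from Compound 3 to Compound 4

The source may report more compounds than this note shows. Statements on the series, on what has been measured and on what is new or still open speak of the compounds shown alone.

Three compounds have numbers in an assay for inhibition of RAC-alpha serine/threonine-protein kinase (Homo sapiens), read by HTRF, with a stated time of 1 h; on this read-out higher numbers stand for weaker inhibition and lower numbers for stronger inhibition. Compound 1 `Cn1ncc(Cl)c1-c1cc(C(=O)N[C@H]2CNCC[C@@H]2c2ccc(C(F)(F)F)cc2)oc1Cl` gives 127 nM. Compound 2 `Cn1ncc(Cl)c1-c1cc(C(=O)N[C@@H]2CN[C@H](CC(=O)NC3CC3)C[C@H]2c2ccc(Cl)c(Cl)c2)oc1Cl` gives 3.95 nM. Compound 3 `Cn1ncc(Cl)c1-c1cc(C(=O)N[C@@H]2CN[C@H](CCO)C[C@H]2c2ccc(F)c(F)c2)oc1Cl` gives 0.98 nM, the lowest of the three; its nearest neighbour is compound 2, with a higher number beyond the scatter, and compound 1 lies further off, also beyond the scatter.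

Compound 4 `CNC(=O)C[C@@H]1C[C@@H](c2ccc(F)c(F)c2)[C@H](NC(=O)c2cc(-c3c(Cl)cnn3C)c(Cl)o2)CN1` is not yet measured in this assay. Its difference from compound 3 reads (methylcarbamoyl in place of hydroxymethyl on a saturated chain carbon bound to a saturated ring carbon). Going by the values given here, compound 2 also bears a carbamoyl-containing chain, but it differs from compound 3 in more than one place, so no clean single-point step exists for this change. In this assay the step is expected to be small, a 1.8-fold higher number from compound 3 to compound 4 (0.26 log units; within the scatter), at most a modest move towards a higher number. Compound 4 is expected to give about 1.8 nM in this assay, within a range from 0.6 nM to 6 nM.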

Compound 4, half-maximal inhibitory concentration: 1.37 nM
Beside the measured number, compound 4's estimate is 1.3-fold (0.12 log units) above it; measured number inside the range.
By their numbers in this assay, from the lowest: compounds 3 and 4 (each within the scatter of the next); then compound 2; then compound 1.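

In this assay, going by these compounds alone, putting methylcarbamoyl in place of hydroxymethyl gives a 1.4-fold higher number from compound 3 to compound 4 (0.15 log units; within the scatter), the first step that differs in this one place. On a saturated chain carbon bound to a saturated ring carbon, the larger methylcarbamoyl group therefore stands in for hydroxymethyl with no difference beyond the scatter, and the two groups have matching hydrogen-bond donor and acceptor counts. No supporting measurement bears on why these two groups read alike. The compounds shown leave open how a carboxylic acid, an amine or a longer chain would read at this place.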